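Series notes: aryl change from compound 1 to compound 4

The compounds below may be only part of what the source reports. "The series", "measured", "known", "first", "only" and "open" are said of these compounds alone.

Compound 1 `O=C1C(O)=C(C(c2ccc(F)cc2)c2c[nH]c3ccccc23)C(=O)c2ccccc21` gives 28100 nM in a functional assay on ECa-109 cells (Homo sapiens) for cytotoxicity, read by MTT assay, with a stated time of 48 h (on this read-out lower numbers stand for stronger inhibition and higher numbers for weaker inhibition), the second highest of the three numbers recorded so far. Compound 3 `COc1cccc(C(C2=C(O)C(=O)c3ccccc3C2=O)c2c[nH]c3ccccc23)c1` gives 40000 nM, and compound 2 `Cc1[nH]c2ccccc2c1C(C1=C(O)C(=O)c2ccccc2C1=O)c1ccc(Cl)cc1` gives 14300 nM; both numbers stand within the scatter of compound 1. Compound 4 `O=C1C(O)=C(C(c2cccc([N+](=O)[O-])c2)c2c[nH]c3ccccc23)C(=O)c2ccccc21` differs from compound 1 by 3-nitrophenyl in place of 4-fluorophenyl on a saturated chain carbon bound to an aromatic carbon and a double-bonded ring carbon. Within the data shown here, the one measured step at the same place, a 1.4-fold higher number from compound 1 to compound 3 (0.15 log units; within the scatter), stayed within the scatter. Among the measured compounds shown here, no measured compound carries a nitrophenyl group, so the change is not covered directly; the only related change left the number essentially where it was. For compound 4 the expected step is therefore a 1.1-fold higher number from compound 1 to compound 4 (0.03 log units; within the scatter), that is, nothing beyond the scatter. Compound 4 is estimated at 30000 nM, with a range of 10000 nM to 90000 nM.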

Compound 4, half-maximal inhibitory concentration: 36200 nM
Compound 4: middle estimate off by 1.2-fold (0.08 log units), on the low side; measured number inside the range.
By their numbers in this assay, from the lowest: compounds 2, 1, 4 and 3 (each within the scatter of the next, the first and the last beyond it).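

In this assay the nitro group brings no shift at this place: 3-nitrophenyl in place of 4-fluorophenyl gives a 1.3-fold higher number from compound 1 to compound 4 (0.11 log units; within the scatter), and nitro in place of methoxy on an aromatic carbon gives a 1.1-fold lower number from compound 3 to compound 4 (0.04 log units; within the scatter). Compounds 1, 3 and 4 thus all lie within the scatter of one another, even with the two hydrogen-bond acceptors that 3-nitrophenyl adds. No evidence on hand accounts for this flat response.

On these data alone, whether an amine or a carboxylic acid on this aromatic ring would move the number beyond the scatter stays open. Compound 2 differs from compound 1 in more than one place, so its number cannot be tied to a single change.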